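The source may hold more compounds than are shown below. What is called first, only, known or untested is meant among the compounds shown, and "the series" means these compounds.

Measured compounds:
compound 1 `COC(=O)CCNC(=O)[C@@H]1CC=C(CCC=C(C)C)C[C@H]1c1ccccc1` — > 23000 nM
compound 2 `COC(=O)CCNC(=O)[C@H]1CC=C(CCC=C(C)C)C[C@@H]1c1ccccc1` — 3100 nM
compound 3 `CON(C)C(=O)[C@@H]1CC=C(CCC=C(C)C)C[C@H]1c1ccccc1` — > 23000 nM

In an assay on isolated protein for inhibition of Apoptosis regulator Bcl-2 (Homo sapiens), read by fluorescence polarization, with stated times of 5 min and 10 min (a higher number here means a weaker inhibitor, a lower number a stronger inhibitor), compound 1 gives > 23000 nM, which is a limit of the assay rather than a number. Its mirror image, compound 2, gives 3100 nM, so the step of an at least 7.4-fold lower number from compound 1 to compound 2 (0.87 log units; beyond the scatter) is clear. Compound 3 gives > 23000 nM, again a limit. The step that the two limits leave unreadable from compound 1 to compound 3 therefore cannot be sized, because of the limit of > 23000 nM in this assay, at which 2 of the 3 values shown sit.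

Compound 4 `COC(=O)c1ccc(NC(=O)[C@@H]2CC=C(CCC=C(C)C)C[C@H]2c2ccccc2)cc1` is made from compound 1 by 4-(methoxycarbonyl)phenyl in place of 2-(methoxycarbonyl)ethyl on an amide-type nitrogen. Going by the values given here, the only measured step at the same amide nitrogen is a step that the two limits leave unreadable from compound 1 to compound 3, and it tells nothing about size or direction. With compound 1 itself known only as a limit, a step about the size of an at least 1.1-fold lower number from compound 1 to compound 4 (0.06 log units; that floor lies within the scatter) is expected, and compound 4 is estimated at 20000 nM (range 5000 nM to 80000 nM).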

Compound 4, inhibition constant: > 23000 nM
Compound 4 was reported as a limit (the forecaster's own chance of this, stated with the estimate: 55%); middle value at least 1.1-fold (0.06 log units) from the limit.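

In this assay, going by these compounds alone, compound 4 gives > 23000 nM, a limit of the assay and not a number; compound 1 is also a limit, so no step between them can be read. The compounds shown leave open how much 4-(methoxycarbonyl)phenyl in place of 2-(methoxycarbonyl)ethyl changes the inhibition.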